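The source may hold more compounds than are shown below. What is called first, only, known or untested is meant among the compounds shown, and "the series" means these compounds.

Values measured in an ADME assay on MT4 cells (Homo sapiens) for cytotoxicity, read by MTT assay; a lower number here means that less compound is tolerated, a higher number that more compound is tolerated:

- Compound 1 `O=C1c2ccccc2C(=O)N1CCOC(=S)N(C(=O)c1ccccc1[N+](=O)[O-])c1ccc(Cl)cc1`: 21000 nM
- Compound 2 `O=C1c2ccccc2C(=O)N1CCOC(=S)N(C(=O)c1cccc(F)c1F)c1ccc(Cl)cc1`: 58000 nM
- Compound 3 `O=C1c2ccccc2C(=O)N1CCOC(=S)N(C(=O)c1ccc(F)cc1F)c1ccc(Cl)cc1`: 52000 nM

All three compounds share one core and differ only in the aryl group on a carbonyl carbon. Compound 3, at 52000 nM, belongs with compound 2 in the upper pair of the three numbers, since the two cannot be told apart: a 1.1-fold lower number from compound 2 to compound 3 (0.05 log units; within the scatter). Compound 1 stands clearly apart: a 2.5-fold higher number from compound 1 to compound 3 (0.39 log units; beyond the scatter).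

The next compound is compound 4 `O=C1c2ccccc2C(=O)N1CCOC(=S)N(C(=O)c1ccc(Cl)cc1Cl)c1ccc(Cl)cc1`, which has 2,4-dichlorophenyl in place of 2,4-difluorophenyl on a carbonyl carbon. For the measured compounds named here, no measured step makes this exchange, so the evidence is indirect. Replacing the 2-nitrophenyl group gave modest steps, a 2.8-fold higher number from compound 1 to compound 2 (0.44 log units; beyond the scatter) and a 2.5-fold higher number from compound 1 to compound 3 (0.39 log units; beyond the scatter), and these mark the largest change seen at this place. Swapping one difluorophenyl group for the other gave a 1.1-fold lower number from compound 2 to compound 3 (0.05 log units; within the scatter). With only these steps as a guide, no step beyond the scatter is expected in this assay, though there is a slight lean towards a lower number, in the direction of compound 1. The expected step is a 1.3-fold lower number from compound 3 to compound 4 (0.11 log units; within the scatter). For compound 4 the estimated value is 40000 nM, with an expected range of 18000 nM to 80000 nM.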

Compound 4, half-maximal cytotoxic concentration: 18000 nM
Compound 4: middle estimate off by 2.2-fold (0.35 log units), on the high side, within the range that was stated.
By their numbers in this assay, from the lowest: compounds 4 and 1 (each within the scatter of the next); then compounds 3 and 2 (each within the scatter of the next).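

In this assay, the identity of the halogen on this aryl group turns out to matter: 2,4-dichlorophenyl in place of 2,4-difluorophenyl gives a step beyond the scatter (a 2.9-fold lower number from compound 3 to compound 4 (0.46 log units; beyond the scatter)), although the two difluorophenyl groups could not be told apart, and the step from the other difluorophenyl compound is of similar size (a 3.2-fold lower number from compound 2 to compound 4 (0.51 log units; beyond the scatter)). The new compound also falls level with the nitro compound (a 1.2-fold lower number from compound 1 to compound 4 (0.07 log units; within the scatter)), so among these four compounds, the 2-nitrophenyl and 2,4-dichlorophenyl groups form the lower pair and the two difluorophenyl groups form the upper pair, which means that the lower numbers are not confined to the nitro compound. Nothing available explains why the chlorine compound sits with the nitro compound rather than with its fluorine counterparts.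

The compounds shown leave open whether both chlorines are needed for this step, a question that a phenyl group carrying one chlorine and one fluorine could address, and where an unsubstituted phenyl or a methoxyphenyl group would fall. For the compounds shown here, only this aryl group varies here, so it also remains open whether the same exchange would give a similar step with a different group elsewhere on the shared core.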